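The compounds below may be only part of what the source reports. "The series", "measured", "known", "first", "only" and "open" are said of these compounds alone.

Compound 3 `COc1ccc(CN(C(=O)CSc2nc3ccccc3s2)c2cc(OC)c(OC)c(OC)c2)cc1C` belongs to a small set of amides that share one core. In a functional assay on PC-3 cells (Homo sapiens) for antiproliferative activity, read by MTT assay, with a stated time of 48 h (a higher number here means a weaker inhibitor, a lower number a stronger inhibitor), compound 3 gives 34300 nM, the second highest of the three numbers in hand. Compound 1 `COc1cc(N(Cc2ccccc2)C(=O)CSc2nc3ccccc3s2)cc(OC)c1OC` carries a plain phenyl where compound 3 has its 4-methoxy-3-methylphenyl. In this assay, going by the values given here, compound 1 gives 54100 nM, and the step of a 1.6-fold lower number from compound 1 to compound 3 (0.20 log units; within the scatter) is the only one-place comparison available. Compound 2 `COc1ccc2nc(SCC(=O)N(Cc3ccc(OC)c(O)c3)c3cc(OC)c(OC)c(OC)c3)sc2c1` differs from compound 3 in several places. In this assay compound 2 gives 4110 nM, and the gap between compound 3 and compound 2 lies beyond the scatter.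

The next compound, compound 4 `COc1ccc(CN(C(=O)CSc2nc3ccccc3s2)c2cc(OC)c(OC)c(OC)c2)cc1N`, differs from compound 3 by amino in place of methyl on an aromatic carbon. Among the compounds with values here, no measured step exchanges a methyl for an amino group, so the one relevant step, a 1.6-fold lower number from compound 1 to compound 3 (0.20 log units; within the scatter), shows only that decorating this ring moved the number little. The two values of compound 2 and compound 3 show that a changed ring, together with a change on the core, went with a lower number. Compound 4 is therefore expected to give 20000 nM, with the likely range 7000 nM to 60000 nM, the expected step being a 1.7-fold lower number from compound 3 to compound 4 (0.23 log units; within the scatter).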

Compound 4, half-maximal inhibitory concentration: 7510 nM
For compound 4 the middle estimate is 2.7-fold (0.43 log units) above the measured one; low and high end bracket the measured number.
By their numbers in this assay, from the lowest: compounds 2 and 4 (each within the scatter of the next); then compounds 3 and 1 (each within the scatter of the next).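

Swapping methyl for amino on this aromatic carbon, ortho to a methoxy group, gives in this assay a 4.6-fold lower number from compound 3 to compound 4 (0.66 log units; beyond the scatter), so this one position can move the number beyond the scatter, which no earlier one-place comparison had shown. Measured against the plain phenyl, the 3-amino-4-methoxyphenyl group gives a 7.2-fold lower number from compound 1 to compound 4 (0.86 log units; beyond the scatter), whereas the 4-methoxy-3-methylphenyl group had stayed within the scatter of the phenyl, so decorating the ring matters here only with amino in this position, not with methyl. The count of one hydrogen-bond donor and one hydrogen-bond acceptor entering with the amino group describes the swap but does not explain it, and nothing measured here speaks to why the number fell.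

From the compounds shown here alone, whether the amino group itself matters or other groups at this position would do the same remains open, as a dimethylamino group, an acetamide or a fluorine in its place would be needed to tell. Also open, going by these compounds, is whether the step holds on other versions of the shared core and in cell lines other than the one tested here.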